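Swapping the aryl substituent: does clearance stay high?

This account rests on a few compounds, and the source may have more. Where it says the series, first, only, none or still open, it means among the compounds named here.

Measured compounds:
- compound 1, `COc1cc(C(O)(C(F)(F)F)C(F)(F)F)cnc1N1CCN(S(=O)(=O)c2ccc(N)nc2)CC1`; in an ADME assay (liver) for metabolic stability, with Liver microsome (Rattus norvegicus) as the target, using microsomes and NADPH, with a stated time of 30 min, tested at 1 uM (a higher number here means faster removal of the compound, a lower number slower removal), compound 1 sits at the assay limit, < 14 mL.min-1.g-1.
- compound 2, `COCC#Cc1cc(C(O)(C(F)(F)F)C(F)(F)F)cnc1N1CCN(S(=O)(=O)c2ccc(N)nc2)CC1`; in this assay compound 2 gives 399 mL.min-1.g-1.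
- compound 3, `Cc1ccc(-c2cc(C(O)(C(F)(F)F)C(F)(F)F)cnc2N2CCN(S(=O)(=O)c3ccc(N)nc3)CC2)cn1`; in this assay compound 3 gives 182 mL.min-1.g-1.

The value for compound 1 is only a limit, not a number, as noted (the limit of < 14 mL.min-1.g-1 in this assay, at which 1 of the 3 values shown sits). Among the two numbers, compound 3 stands lowest, with compound 2 nearest, a 2.2-fold lower number from compound 2 to compound 3 (0.34 log units; beyond the scatter). The two measured steps from compound 1 are both large: an at least 28-fold higher number from compound 1 to compound 2 (1.45 log units; beyond the scatter) and an at least 13-fold higher number from compound 1 to compound 3 (1.11 log units; beyond the scatter).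

Compound 4, `Nc1ccc(S(=O)(=O)N2CCN(c3ncc(C(O)(C(F)(F)F)C(F)(F)F)cc3-c3cccc4[nH]ncc34)CC2)cn1`, is not yet measured. It differs from compound 3 in one place: 1H-indazol-4-yl in place of 6-methylpyridin-3-yl on an aromatic carbon. Within the data shown here, no measured step changes one aryl group for another, so the closest guide is compound 3 itself together with the modest gap a 2.2-fold lower number from compound 2 to compound 3 (0.34 log units; beyond the scatter). Compound 4 is therefore expected to remain in the faster-clearance region, with a step of a 1.1-fold lower number from compound 3 to compound 4 (0.06 log units; within the scatter) that need not exceed the scatter. The estimate for compound 4 is 160 mL.min-1.g-1, within 50 mL.min-1.g-1 to 500 mL.min-1.g-1.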

Compound 4, intrinsic clearance in microsomes: 93 mL.min-1.g-1
Beside the measured number, compound 4's estimate is 1.7-fold (0.24 log units) above it; low and high end bracket the measured number.
By their numbers in this assay, from the lowest: compounds 4 and 3 (each within the scatter of the next); then compound 2. At a limit, below all of these: compound 1.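

Among these compounds, compound 4 gives the first step that exchanges one aryl group for another at this position, and in this assay that step is a 2.0-fold lower number from compound 3 to compound 4 (0.29 log units; within the scatter), so the larger 1H-indazol-4-yl, with its hydrogen-bond donor, cannot be told apart from 6-methylpyridin-3-yl here. The change from the open chain to 1H-indazol-4-yl is clearer, at a 4.3-fold lower number from compound 2 to compound 4 (0.63 log units; beyond the scatter). Methoxy still stands apart, with an at least 6.6-fold higher number from compound 1 to compound 4 (0.82 log units; beyond the scatter), and this step is only a bound, as compound 1 gives a limit rather than a number: the limit of < 14 mL.min-1.g-1 in this assay, at which 1 of the 4 values shown sits.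

On these data alone, whether a small group such as an amine or an ethoxy group at this position would fall with compound 1 or with the larger groups stays open. Also open, as far as these compounds go, is whether the hydrogen on the ring nitrogen of 1H-indazol-4-yl plays any part in the number for compound 4.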